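The source may hold more compounds than are shown below. What is called first, only, known or untested is meant among the compounds shown, and "the series" means these compounds.

Working notes on the series. Within the data shown here, in a functional assay on the whole organism (Tail, strain ICR) with Mus musculus as the target, in the tail flick test, with a stated time of 30 min, at a dose of 25 umol/kg by the oral route (on this read-out lower numbers stand for a weaker effect and higher numbers for a stronger effect at the one dose given), compound 1 `N=C(N)NCCC[C@H](NC(=O)CN(c1ncnc2c1ncn2C1CCCCO1)C1CC1)C(=O)OCc1ccccc1` gives 34.3%, the second highest of the three numbers so far. Compound 2 `C[C@H](NC(=O)CN(c1nc(Cl)nc2[nH]cnc12)C1CC1)C(=O)O` gives 48.1%, a number beyond the scatter above compound 1; compound 3 `O=C(CN(c1nc(Cl)nc2[nH]cnc12)C1CC1)NCC(=O)OCc1ccccc1` gives 18.7%, a number beyond the scatter below compound 1. The step of interest leads from compound 1 to compound 4 `C[C@H](NC(=O)CN(c1ncnc2c1ncn2C1CCCCO1)C1CC1)C(=O)OCc1ccccc1`, which has not yet been run in this assay. The change is a hydrogen atom in place of a group of 6 heavy atoms (3 carbon, 3 nitrogen; no ring), on a saturated chain carbon, two bonds along the chain from an amide-type nitrogen and a carbonyl carbon. Among the measured compounds shown here, no measured pair shows this change, so the expected step in this assay is taken as small, a modest downward move at most, not reliably beyond the scatter, because compound 1 with 34.3% sits between its two neighbours. Compound 4 is therefore estimated at 30%, with a range from 12% to 50%; the expected step is a number 4.3 percentage points lower from compound 1 to compound 4 (within the scatter).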

Compound 4, a percentage reported as activity, at one dose (the size of the read-out at that dose, not a potency): 55.9%
Compound 4: the middle estimate sits 25.9 percentage points below what was measured; the measured number lies above the stated range.
By their numbers in this assay, from the lowest: compound 3; then compound 1; then compounds 2 and 4 (each within the scatter of the next).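

In this assay this position gives its first readable step, a number 21.6 percentage points higher from compound 1 to compound 4 (beyond the scatter), with a hydrogen atom in place of the group of 6 heavy atoms (3 carbon, 3 nitrogen; no ring). In this pair, that group is therefore not required for the effect at the one dose given, and the read-out is higher without it. Nothing on hand gives a cause for the step.

One pair leaves open how a simple amine or a hydroxyl at the end of a shorter chain on this carbon would read. Going by these compounds, whether the step carries over to the core of compound 2 also stays open.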